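The compounds below may be only part of what the source reports. "The series", "measured", "known", "first", "only" and "open" are said of these compounds alone.

Of the compounds shown here, three of a shared core have been measured in a physicochemical assay for solubility, in phosphate buffer, measured as kinetic solubility; on this read-out lower numbers stand for lower solubility and higher numbers for higher solubility. Compound 1 `CC(C)C(Cc1nnc[nH]1)c1ccc(-c2ccc3cccc(F)c3c2)[nH]c1=O` gives 24200 nM. Compound 2 `CC(C)C(c1nnc[nH]1)c1ccc(-c2ccc3cccc(F)c3c2)[nH]c1=O` gives 24500 nM, which places it second highest of the three numbers, with compound 1 nearest and compound 3 furthest. Compound 3 `CC(C)C(c1noc(=O)[nH]1)c1ccc(-c2ccc3cccc(F)c3c2)[nH]c1=O` gives 32500 nM. All three steps among them exchange the group on the saturated chain carbon bound to an aromatic carbon and a saturated chain carbon: a 1.0-fold higher number from compound 1 to compound 2 (0.01 log units; within the scatter), a 1.3-fold higher number from compound 1 to compound 3 (0.13 log units; within the scatter) and a 1.3-fold higher number from compound 2 to compound 3 (0.12 log units; within the scatter), each within the scatter.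

Compound 4 `Cc1c[nH]c(C(c2ccc(-c3ccc4cccc(F)c4c3)[nH]c2=O)C(C)C)n1` has not yet been measured in this assay. It differs from compound 2 in the same place: 4-methyl-1H-imidazol-2-yl in place of 4H-1,2,4-triazol-3-yl on a saturated chain carbon bound to an aromatic carbon and a saturated chain carbon. The three measured steps, which likewise swap a five-membered aromatic ring on that carbon, bear on this change, and none of them moved the read-out beyond the scatter. For compound 4 the step is therefore expected to be a 1.2-fold lower number from compound 2 to compound 4 (0.09 log units; within the scatter), with no direction resolved beyond the scatter. Compound 4 is estimated at 20000 nM, within a range from 9000 nM to 45000 nM.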

Compound 4, solubility: 15200 nM
Compound 4: the middle estimate sits 1.3-fold (0.12 log units) above what was measured; low and high end bracket the measured number.
By their numbers in this assay, from the lowest: compounds 4, 1, 2 and 3 (each within the scatter of the next, the first and the last beyond it).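

In this assay, 4-methyl-1H-imidazol-2-yl gives the first step among these groups on the saturated chain carbon that goes beyond the scatter (a 2.1-fold lower number from compound 3 to compound 4 (0.33 log units; beyond the scatter)), although this step is modest. The other two steps stay within the scatter (a 1.6-fold lower number from compound 2 to compound 4 (0.21 log units; within the scatter); a 1.6-fold lower number from compound 1 to compound 4 (0.20 log units; within the scatter)), so the new group stands apart from only one of the three earlier groups, and the position is no longer flat across every group shown. Among the compounds shown here, no measurement at hand accounts for the one step beyond the scatter.

The compounds shown do not separate the methyl group from the exchange of the ring itself, a question that an unsubstituted 1H-imidazol-2-yl would address. They also leave open how this position responds to groups other than five-membered aromatic rings, such as an amine or a carboxylic acid.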